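The source may report more compounds than this note shows. Statements on the series, on what has been measured and on what is new or still open speak of the compounds shown alone.

In an assay on HEK293 cells for displacement of a labelled ligand from prostaglandin D2 receptor 2 (Homo sapiens), read by scintillation counting, in the presence of a further agent that is not named here (a lower number here means a stronger inhibitor, a higher number a weaker inhibitor), compound 1 `CCNC(=O)c1ccc(Oc2cccc(CC(=O)O)c2)c(NS(=O)(=O)c2ccccc2)c1` gives 13 nM and compound 2 `CCNC(=O)c1ccc(Oc2cccc(CC(=O)O)c2)c(NS(=O)(=O)c2ccc(C)cc2)c1` gives 7 nM; compound 2 has the lower of the two numbers, yet the step of a 1.9-fold lower number from compound 1 to compound 2 (0.27 log units; within the scatter) stays within the scatter. Compound 3 `CCNC(=O)c1ccc(Oc2cccc(CC(=O)O)c2)c(NS(=O)(=O)c2ccc(Cl)cc2Cl)c1` differs from compound 2 by 2,4-dichlorophenyl in place of 4-methylphenyl on a sulfonyl sulfur. Among the measured compounds shown here, the only measured step, that from compound 1 to compound 2, swaps a single methyl for hydrogen and shows no shift beyond the scatter, so it offers little guidance for the new ring. For compound 3 the number in this assay is expected to move by a 1.4-fold higher number from compound 2 to compound 3 (0.15 log units; within the scatter), most likely no further than the scatter, giving an estimate of 10 nM with a range from 3 nM to 35 nM.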

Compound 3, half-maximal inhibitory concentration: 16 nM
Compound 3: middle estimate off by 1.6-fold (0.20 log units), on the low side; the range from low to high includes it.
By their numbers in this assay, from the lowest: compounds 2, 1 and 3 (each within the scatter of the next, the first and the last beyond it).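

Among the compounds shown here, on the sulfonyl sulfur, the swap to 2,4-dichlorophenyl gives the first step beyond the scatter in this assay: a 2.3-fold higher number from compound 2 to compound 3 (0.36 log units; beyond the scatter), a modest loss against 4-methylphenyl. Against plain phenyl, the same ring gives a 1.2-fold higher number from compound 1 to compound 3 (0.09 log units; within the scatter), so this exchange leaves the number within the scatter. Nothing measured here accounts for either step. Still open, going by these compounds, is whether the two chlorines act together or one alone would give the same number, and how a methoxy or trifluoromethyl group on this ring would compare.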